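Pyridin-3-yl Replaces 4-Chlorophenyl on the Alkyne

The source may report more compounds than this note shows. Statements on the series, on what has been measured and on what is new or still open speak of the compounds shown alone.

In an assay on CHO cells for displacement of a labelled ligand from adenosine receptor A1 (Homo sapiens), read by scintillation counting, with a stated time of 60 min, tested at 10 uM (a higher number here means more inhibition at the concentration tested (going by the name of the read-out), a lower number less inhibition), compound 2 `CNC(=O)[C@@]12C[C@@H]1[C@@H](n1cnc3c(NC)nc(C#Cc4ccc(Cl)cc4)nc31)[C@H](O)[C@@H]2O` gives 13%, the lower of the two numbers shown, though within the scatter of compound 1 `CNC(=O)[C@@]12C[C@@H]1[C@@H](n1cnc3c(NC)nc(C#Cc4ccccc4)nc31)[C@H](O)[C@@H]2O`, which gives 18%; the only measured step, a number 5 percentage points lower from compound 1 to compound 2 (within the scatter), was small. Compound 3 `CNC(=O)[C@@]12C[C@@H]1[C@@H](n1cnc3c(NC)nc(C#Cc4cccnc4)nc31)[C@H](O)[C@@H]2O` differs from compound 2 by pyridin-3-yl in place of 4-chlorophenyl on a triple-bonded carbon. Among the measured compounds shown here, no measured step exchanges a carbon-only ring for one with a hetero atom, so that single small step is the sole guide. Compound 3 is therefore expected to shift by no change at the digits printed from compound 2 to compound 3 (within the scatter), nothing beyond the scatter. Compound 3 is estimated at 13%, within 0% to 30%.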

Compound 3, a percentage reported as inhibition, at one concentration (the size of the read-out at that concentration, not a potency): 16%
The estimate for compound 3 lay 3 percentage points below the measured number, and the stated range covers the measured number.
By their numbers in this assay, from the lowest: compounds 2, 3 and 1 (each within the scatter of the next).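

Exchanging a carbon-only ring for pyridin-3-yl on a triple-bonded carbon gives a number 3 percentage points higher from compound 2 to compound 3 (within the scatter) and a number 2 percentage points lower from compound 1 to compound 3 (within the scatter) in this assay at the concentration tested. A ring with a hetero atom at this position therefore stays within the scatter of both phenyl and 4-chlorophenyl. No evidence is available that bears on this result. Still open, on these data alone, is whether an amine, a carboxylic acid or a longer chain on the triple-bonded carbon would move the number beyond the scatter. Pyridin-3-yl is also the only ring with a hetero atom shown here.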